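A few compounds are considered here, and "the series" means these few. Any claim that something is new, unique, unknown or untested is made for them only; others in the source may bear on it.

Compound 1 `c1ccc2c(c1)CN[C@@H](CN(CCCCNC1CCCCC1)[C@H]1CCCc3cccnc31)C2`: in a functional assay on cells for agonist activity at C-X-C chemokine receptor type 4 (Homo sapiens), read by fluorescence and calcium flux, with a stated time of 90 s (a higher number here means that more compound is needed for the effect, a lower number that less compound is needed), compound 1 gives > 30000 nM, which is a limit of the assay and not a number.
Compound 2 `FC1(F)CCC(NC/C=C/CN(C[C@H]2Cc3ccccc3CN2)[C@H]2CCCc3cccnc32)CC1`: in this assay compound 2 gives > 30000 nM, again a limit rather than a number.
Compound 3 `CC1(C)CCC(NC/C=C/CN(C[C@H]2Cc3ccccc3CN2)[C@H]2CCCc3cccnc32)CC1`: in this assay compound 3 gives > 30000 nM, also a limit rather than a number.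

Compound 3 therefore stands at the edge of what this assay can report, and so do its two companions, as the limit of > 30000 nM in this assay, at which 3 of the 3 values shown sit, records. Within the data shown here, the one measured step that differs in a single place, a step that the two limits leave unreadable from compound 2 to compound 3, cannot be read in size, since both of its ends are limits; it shows only that swapping one saturated ring for another left the compound unmeasurable.

Compound 4 `C(=C/CN(C[C@H]1Cc2ccccc2CN1)[C@H]1CCCc2cccnc21)\CNCc1cccnc1` departs from compound 3 by (pyridin-3-yl)methyl in place of 4,4-dimethylcyclohexyl on an amine nitrogen. Among the measured compounds shown here, no measured step speaks to this change with a readable size, and every measured compound sits at the same limit. The expectation for compound 4 in this assay is thus no more than a guess anchored to that limit: compound 4 is estimated at 30000 nM, with a range from 5000 nM to 100000 nM. This corresponds to an expected step of a number no higher from compound 3 to compound 4 (the limit leaves the size open), with a fair chance that only a limit is reported again.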

Compound 4, half-maximal effective concentration: > 30000 nM
Compound 4: no number, only a limit; the forecaster's own chance of this, stated with the estimate: 70%; the middle value lies on the limit itself.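

Compound 4, like compound 1, compound 2 and compound 3, gives only a limit and not a number, so none of the steps joining compound 4 to those three can be read in size: the limit of > 30000 nM in this assay, at which 4 of the 4 values shown sit. The compounds shown leave open whether any group on this amine nitrogen would give a measurable value in this assay.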